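Removing the Chlorine from the Furan of Compound 3

The source may hold more compounds than are shown below. What is called first, only, known or untested is meant among the compounds shown, and "the series" means these compounds.

Measured compounds:
- compound 1 `Clc1ccc(-c2cc(-c3cccs3)nc(-c3ccccc3Cl)c2)o1`: 6190 nM
- compound 2 `Clc1ccc(-c2cc(-c3ccoc3)cc(-c3cccs3)n2)cc1`: 50000 nM
- compound 3 `Clc1ccc(-c2cc(-c3ccc(Cl)o3)cc(-c3cccs3)n2)cc1`: 14200 nM

In a functional assay on HCT-15 cells (Homo sapiens) for cytotoxicity, in the presence of a further agent that is not named here (on this read-out lower numbers stand for stronger inhibition and higher numbers for weaker inhibition), compound 3 stands second highest of the three numbers; its nearest neighbour is compound 1, with a 2.3-fold higher number from compound 1 to compound 3 (0.36 log units; beyond the scatter), and its furthest is compound 2, with a 3.5-fold lower number from compound 2 to compound 3 (0.55 log units; beyond the scatter).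

Compound 4 `Clc1ccc(-c2cc(-c3ccco3)cc(-c3cccs3)n2)cc1` differs from compound 3 by hydrogen in place of chloro on an aromatic carbon, read one bond further out as 5-chlorofuran-2-yl to furan-2-yl. Within the data shown here, the step bearing on it is the one from compound 2 to compound 3, where a chlorine-bearing furan gave a modestly lower number; taking the chlorine away again is therefore expected to move the number back up, by about a 2.1-fold higher number from compound 3 to compound 4 (0.32 log units; beyond the scatter). Compound 4 is estimated at 30000 nM, within 10000 nM to 80000 nM.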

Compound 4, half-maximal inhibitory concentration: > 100000 nM
Compound 4 gave a limit, no number; the forecaster's own chance of this, stated with the estimate: 25%; middle value at least 3.3-fold (0.52 log units) from the limit.
By their numbers in this assay, from the lowest: compound 1; then compound 3; then compound 2. At a limit, above all of these: compound 4.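

Compound 4 gives only a limit in this assay, not a number: the limit of > 100000 nM in this assay, at which 1 of the 4 values shown sits.

Among these compounds, removing the chloro from the carbon next to the ring oxygen gives an at least 7.0-fold higher number from compound 3 to compound 4 (0.84 log units; beyond the scatter), so this single atom matters more on the furan-2-yl compounds than the earlier steps could show. The comparison of the two unsubstituted furans gives an at least 2.0-fold higher number from compound 2 to compound 4 (0.30 log units; that floor lies within the scatter), so furan-2-yl and furan-3-yl cannot be ranked.

The compounds shown leave open whether chlorine itself is needed on this carbon, or whether bromine or a methyl group would serve equally well. Going by these compounds, the true size of the loss also stays open.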